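Chloro in Place of Methyl, Carried from One Core to Another

The compounds below may be only part of what the source reports. "The series", "measured", "known", "first", "only" and "open" are said of these compounds alone.

Of the compounds shown here, three have been measured in an assay on HEK293 cells for inhibition of N-acylethanolamine-hydrolyzing acid amidase (Rattus norvegicus), read by LC-MS, with a stated time of 30 min; on this read-out higher numbers stand for weaker inhibition and lower numbers for stronger inhibition. Compound 1 `O=C1OCCN1C(=O)c1ccc(Oc2cccc(Cl)c2)cc1` gives 7740 nM in this assay. Compound 2 `Cc1cccc(Oc2ccc(C(=O)N3CCOC3=O)cc2)c1` gives 5210 nM in this assay. The two differ by chloro in place of methyl on an aromatic carbon, and the step of a 1.5-fold higher number from compound 2 to compound 1 (0.17 log units; within the scatter). Compound 3 `Cc1ccccc1CCCCCC(=O)N1CCOC1=O` carries a different core; how the core of compound 3 differs from the core of compound 2 is not broken down here. In this assay compound 3 gives > 20000 nM, which is a limit of the assay and not a number.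

Compound 4 `O=C(CCCCCc1ccccc1Cl)N1CCOC1=O` has not yet been measured in this assay. It differs from compound 3 by chloro in place of methyl on an aromatic carbon. The place is not the same word for word as in the pair of compound 2 and compound 1: there the change sits meta to a large group, here it sits ortho to a large group, so it is the same kind of change, not the same change.

Among the measured compounds shown here, the step from compound 3 to compound 4 is expected to be small, a step that the limit leaves unreadable from compound 3 to compound 4, since the one measured step of this kind stayed within the scatter. Because compound 3 already sits at the limit of > 20000 nM in this assay, at which 1 of the 3 values shown sits, compound 4 is expected to give 30000 nM, between 12000 nM and 80000 nM, and most likely to be reported only as a limit again.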

Compound 4, half-maximal inhibitory concentration: > 20000 nM
Compound 4 was reported as a limit (the forecaster's own chance of this, stated with the estimate: 70%); the middle value does not contradict the limit.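

Compound 4 gives > 20000 nM in this assay as a limit of the assay and not a number. No step can be read from compound 3 to compound 4, because both compounds stand at the same limit: the limit of > 20000 nM in this assay, at which 2 of the 4 values shown sit. The compounds shown leave open whether chloro in place of methyl on an aromatic carbon changes the read-out at all on the core of compound 3.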